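Compound 3: the aryl ring on the shared core changes again

The source may report more compounds than this note shows. Statements on the series, on what has been measured and on what is new or still open speak of the compounds shown alone.

Within the data shown here, compound 2 `O=C(CSc1nnc(-c2ccncc2)o1)N/N=C/c1cc(Cl)ccc1O` holds the lowest of the two numbers so far: in a functional assay on HepG2 cells (Homo sapiens) for cytotoxicity, read by MTT assay, with a stated time of 48 h (on this read-out higher numbers stand for weaker inhibition and lower numbers for stronger inhibition), compound 2 gives 3970 nM, while compound 1 `O=C(CSc1nnc(-c2ccncc2)o1)N/N=C/c1ccc(F)cc1` gives 12300 nM. Among the measured compounds shown here, the only measured step, a 3.1-fold lower number from compound 1 to compound 2 (0.49 log units; beyond the scatter), arose from exchanging the aryl ring on the carbon with a double bond to nitrogen. Compound 3 `COc1cc(/C=N/NC(=O)CSc2nnc(-c3ccncc3)o2)ccc1O` alters that same ring once more: 4-hydroxy-3-methoxyphenyl in place of 5-chloro-2-hydroxyphenyl on a carbon with a double bond to nitrogen. For the measured compounds named here, the one step that bears on it shows that a swap at this position can move the number by a modest margin, but it compares compound 1 with compound 2 and not either with compound 3, so it fixes no direction for the new ring. Going by the values given here, because compound 2 already stands at 3970 nM and no step involves compound 3, the expected step is small, a 1.6-fold higher number from compound 2 to compound 3 (0.21 log units; within the scatter), likely a somewhat higher number. The estimate for compound 3 in this assay is 6500 nM, within a range from 2500 nM to 17000 nM.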

Compound 3, half-maximal inhibitory concentration: 2920 nM
Compound 3: the middle estimate sits 2.2-fold (0.35 log units) above what was measured; the range from low to high includes it.
By their numbers in this assay, from the lowest: compounds 3 and 2 (each within the scatter of the next); then compound 1.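

In this assay the exchange of 5-chloro-2-hydroxyphenyl for 4-hydroxy-3-methoxyphenyl gives a 1.4-fold lower number from compound 2 to compound 3 (0.13 log units; within the scatter) and so does not separate these two rings, although the chlorine has gone and a methoxy group has entered. Set against the 4-fluorophenyl ring, the same new ring gives a 4.2-fold lower number from compound 1 to compound 3 (0.62 log units; beyond the scatter) and thus shows that a second ring carrying a hydroxy group also stands apart from compound 1, which carries none. Nothing available explains either step.

Whether the hydroxy group alone accounts for the gap to compound 1 stays open, and so does the effect of an amine or a carboxylic acid on this ring. The shared core is the same in all three compounds, so they say nothing about a change anywhere else.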